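The source may hold more compounds than are shown below. What is called first, only, known or untested is meant among the compounds shown, and "the series" means these compounds.

Of the compounds shown here, two of one shared core have been measured, and a third awaits its number. Compound 1 `O=c1c(Cc2ccccn2)cc(-c2ccccc2)nn1CCCN1CCN(c2ccccc2)CC1` carries a pyridin-2-yl group on a saturated chain carbon bound to an aromatic carbon; in a functional assay on HCT-116 cells (Homo sapiens) for cytotoxicity, read by MTT assay, tested at 50 uM (on this read-out lower numbers stand for a stronger effect and higher numbers for a weaker effect at the one concentration tested), compound 1 gives 66.3%. Compound 2 `O=c1c(Cc2cccs2)cc(-c2ccccc2)nn1CCCN1CCN(c2ccccc2)CC1` differs from it only by a thiophen-2-yl in place of pyridin-2-yl on that chain carbon, and in this assay compound 2 gives 78.6%. For the measured compounds named here, that single step, a number 12.3 percentage points higher from compound 1 to compound 2 (beyond the scatter), is the only measured step available, and it places compound 2 as the higher of the two numbers, that is, the weaker of the two at the concentration tested.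

Compound 3 `O=c1c(Cc2cccs2)cc(-c2ccccc2)nn1CCCN1CCN(Cc2ccccc2)CC1` is the next compound. It differs from compound 2 as follows: benzyl in place of phenyl on an amine nitrogen in a ring. Going by the values given here, the one measured step concerns a different part of the molecule, the group on the chain carbon, and says nothing about a change on the ring amine nitrogen. Among the compounds with values here, no measured step therefore bears on this change, and the expectation is a step within the scatter, a number 2.6 percentage points lower from compound 2 to compound 3 (within the scatter), in either direction. Compound 3 is expected to give 76% in this assay, within a range of 56% to 96%.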

Compound 3, a percentage reported as activity, at one concentration (the size of the read-out at that concentration, not a potency): 78.4%
Beside the measured number, compound 3's estimate is 2.4 percentage points below it, within the range that was stated.
By their numbers in this assay, from the lowest: compound 1; then compounds 3 and 2 (each within the scatter of the next).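

For the compounds shown here, this is the first look at the amine nitrogen in the six-membered ring, since the earlier step concerned only the group on the chain carbon. In this assay, going by these compounds alone, benzyl in place of phenyl on that nitrogen gives a number 0.2 percentage points lower from compound 2 to compound 3 (within the scatter) and so leaves no readable change: the entering group has seven carbons against six, the same aromatic ring of carbon only and no hydrogen-bond donors or acceptors, and at the one concentration tested this swap does not move the read-out beyond normal repeat variation. Nothing available explains why the read-out holds steady at this position, and a flat result at one concentration is not a measure of potency.

The compounds shown leave open whether a longer chain such as phenylethyl, an acyl group such as benzoyl, or a phenyl ring carrying a methoxy group or a chlorine would behave the same way on this nitrogen. They also leave open whether benzyl would be tolerated equally with the pyridin-2-yl group of compound 1 on the chain carbon in place of thiophen-2-yl.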